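Carboxy-hydroxyphenyl for phenyl on the shared core

The source may report more compounds than this note shows. Statements on the series, on what has been measured and on what is new or still open speak of the compounds shown alone.

Measured compounds:
compound 1 `O=C1c2ccc(OCc3cccc(-c4ccccc4)c3)cc2CN1C1CCCC1` — no result
compound 2 `CN(C)C(=O)c1cc(-c2cccc(COc3ccc4c(=O)n(C5CCCC5)sc4c3)c2)ccc1Cl` — 54.8%

In an assay on HEK293 cells for positive allosteric modulation of metabotropic glutamate receptor 2 (Rattus norvegicus), read by thallium flux (a lower number here means a smaller maximal response, a higher number a larger maximal response), compound 1 stands at "not determined" (no result reported), so no single number anchors it. Compound 2 gives 54.8% in this assay. Compound 3 `O=C(O)c1cc(-c2cccc(COc3ccc4c(c3)CN(C3CCCC3)C4=O)c2)ccc1O` differs from compound 1 by 3-carboxy-4-hydroxyphenyl in place of phenyl on an aromatic carbon. For the measured compounds named here, no step between measured compounds shows what this change does; given the value of compound 2, only a step within or slightly beyond the scatter is expected, with no clear direction. Compound 3 is estimated at 50% in this assay, in the range 20% to 85%.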

Compound 3, largest response reached (reported as percent of maximum), in percent of the reference or control that the assay uses: 90.1%
Beside the measured number, compound 3's estimate is 40.1 percentage points below it; measured number outside the range, above it.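

No step can be read from compound 1 at "not determined" (no result reported) to compound 3 at 90.1% in this assay here. On these data alone, what 3-carboxy-4-hydroxyphenyl in place of phenyl does to the maximal response stays open, and no supporting data bear on the result of compound 3.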